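A few compounds are considered here, and "the series" means these few. Any claim that something is new, unique, unknown or untested is made for them only; others in the source may bear on it.

Measured in a functional assay on HOP-92 cells (Homo sapiens) for inhibition, read by sulforhodamine B assay, with a stated time of 48 h; a higher number here means that more compound is tolerated, a lower number that less compound is tolerated:
Compound 1 `COc1cc(-c2nn(-c3cccc(NC(=O)Nc4cc(C(F)(F)F)cc(C(F)(F)F)c4)c3)cc2-c2ccncc2)ccc1Cl` gives 4720 nM.
Compound 2 `COc1cc(-c2nn(-c3cccc(NC(=O)c4cccc(C(F)(F)F)c4)c3)cc2-c2ccncc2)ccc1Cl` gives only a limit of the assay, > 50000 nM.
Compound 3 `O=C(Nc1cccc(-n2cc(-c3ccncc3)c(-c3ccc(Cl)c(O)c3)n2)c1)Nc1ccc(Cl)c(Cl)c1` likewise gives only a limit of the assay, > 32500 nM.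

Compound 2 thus stands at the upper edge of what the assay reports, with no number of its own; compound 3 is the second value shown that is a limit rather than a number (the limit of > 32500 nM in this assay, at which 1 of the 3 values shown sits, (the limit of > 50000 nM in this assay, at which 1 of the 3 values shown sits)). Compound 1 is the only entry with a measured number, and it sits well below both limits.

Compound 4 `COc1cc(-c2nn(-c3cccc(NC(=O)Nc4cccc(C(F)(F)F)c4)c3)cc2-c2ccncc2)ccc1Cl` has not yet been run. It differs from compound 2 in one place: (3-(trifluoromethyl)phenyl)amino in place of 3-(trifluoromethyl)phenyl on a carbonyl carbon. For the measured compounds named here, no step between measured compounds isolates this change. Compound 1 and compound 4 share the urea linkage, but compound 1 also carries a second trifluoromethyl, so its value cannot be carried over directly; compound 3 shows that a urea can also land at a limit. Compound 4 is expected to give a number rather than a limit, with a step from compound 2 of an at least 3.3-fold lower number from compound 2 to compound 4 (0.52 log units; beyond the scatter) toward less tolerated compound. The estimate for compound 4 is 15000 nM, within 4000 nM to 50000 nM.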

Compound 4, concentration lethal to 50% of the cells: > 50000 nM
Compound 4: a limit, no number (the forecaster's own chance of this, stated with the estimate: 35%); middle value at least 3.3-fold (0.52 log units) from the limit.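

In this assay, the urea with (3-(trifluoromethyl)phenyl)amino on the carbonyl carbon does not by itself bring the series down to a measured number, so compound 4 remains at a limit, as does compound 2, and the step between them cannot be read: the limit of > 50000 nM in this assay, at which 2 of the 4 values shown sit.

For the compounds shown here, the pair of compound 1 and compound 4 gives the first readable single change, with hydrogen in place of trifluoromethyl on an aromatic carbon: an at least 10-fold higher number from compound 1 to compound 4 (1.02 log units; beyond the scatter). Within this pair, the measured number therefore goes with the second trifluoromethyl rather than with the urea alone.

On these data alone, whether a second trifluoromethyl would have the same effect on the amide of compound 2 remains open, as does how far compound 2 and compound 4 lie from each other beyond the limit. As far as these compounds go, it is also open whether a nitrile or a tert-butyl group in place of the second trifluoromethyl on the urea would keep a measured number or return to a limit.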